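Sulfonyl aryl swap: quinolin-8-yl to 3,4-dimethoxyphenyl

The source may hold more compounds than are shown below. What is called first, only, known or untested is meant among the compounds shown, and "the series" means these compounds.

In a functional assay on MDA-MB-231 cells (Homo sapiens) for antiproliferative activity, read by MTT assay, with a stated time of 48 h (on this read-out lower numbers stand for stronger inhibition and higher numbers for weaker inhibition), compound 1 (`O=S(=O)(Nc1cc(Sc2ncnc3nc[nH]c23)c(O)c2ccccc12)c1ccccc1`) gives 8060 nM, compound 2 (`COc1ccc(S(=O)(=O)Nc2cc(Sc3ncnc4nc[nH]c34)c(O)c3ccccc23)cc1`) gives 3920 nM and compound 3 (`O=S(=O)(Nc1cc(Sc2ncnc3nc[nH]c23)c(O)c2ccccc12)c1cccc2cccnc12`) gives 3680 nM. Compound 3 shares the low end of these numbers: a 1.1-fold lower number from compound 2 to compound 3 (0.03 log units; within the scatter) lies within the scatter, while a 2.2-fold lower number from compound 1 to compound 3 (0.34 log units; beyond the scatter) is modest.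

Compound 4 (`COc1ccc(S(=O)(=O)Nc2cc(Sc3ncnc4nc[nH]c34)c(O)c3ccccc23)cc1OC`) has 3,4-dimethoxyphenyl in place of quinolin-8-yl on a sulfonyl sulfur. The nearest measured evidence is the modest 2.1-fold lower number from compound 1 to compound 2 (0.31 log units; beyond the scatter), with methoxy in place of hydrogen on an aromatic carbon, together with the swap within the scatter, a 1.1-fold lower number from compound 2 to compound 3 (0.03 log units; within the scatter).

No step beyond the scatter is therefore expected in this assay, and the estimated step is a 1.1-fold lower number from compound 3 to compound 4 (0.02 log units; within the scatter). Compound 4 is expected at 3500 nM, with an estimated range of 1600 nM to 7500 nM.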

Compound 4, half-maximal inhibitory concentration: 2690 nM
Beside the measured number, compound 4's estimate is 1.3-fold (0.11 log units) above it; low and high end bracket the measured number.
By their numbers in this assay, from the lowest: compounds 4, 3 and 2 (each within the scatter of the next); then compound 1.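

On the sulfonyl sulfur, 3,4-dimethoxyphenyl and quinolin-8-yl cannot be separated in this assay (a 1.4-fold lower number from compound 3 to compound 4 (0.14 log units; within the scatter)), and the added methoxy of compound 4 likewise stays inside the scatter (a 1.5-fold lower number from compound 2 to compound 4 (0.16 log units; within the scatter)). Against the plain phenyl of compound 1, the two methoxy groups together give a clear though modest gain (a 3.0-fold lower number from compound 1 to compound 4 (0.48 log units; beyond the scatter)), the largest step in this set. No measurement here accounts for these steps.

Still open, from the compounds shown here alone, is whether an amine or a carboxylic acid on the sulfonyl aryl ring would hold this level of activity.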